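Chloro on the phenyl ring: an untested direction

This account rests on a few compounds, and the source may have more. Where it says the series, first, only, none or still open, it means among the compounds named here.

Measured compounds:
compound 1, `COc1ncc(C(F)(F)F)cc1CO[C@H]1[C@H](C(C)(C)C)[C@@H](C(=O)O)N(C(=O)C2CCCCC2)[C@H]1c1ccccc1`, 150 nM
compound 2, `COc1ncc(C(F)(F)F)cc1CO[C@H]1[C@H](C(C)(C)C)[C@@H](C(=O)O)N(C(=O)OC(C)C)[C@H]1c1ccccc1`, 137 nM
compound 3, `COc1ncc(C(F)(F)F)cc1CO[C@H]1[C@H](C(C)(C)C)[C@@H](C(=O)O)N(C(=O)[C@@H]2CCCCO2)[C@H]1c1ccccc1`, 213 nM

All three were examined in an assay on cells with Cystic fibrosis transmembrane conductance regulator variant F508del (Homo sapiens) as the target, read by voltage clamp, with a stated time of 24 h, in the presence of a further agent that is not named here; on this read-out lower numbers stand for an effect already at smaller amounts and higher numbers for an effect only at larger amounts of compound. Compounds 1, 2 and 3 share one core and differ only in the group on the carbonyl carbon attached to the ring nitrogen. The steps between them are small: a 1.1-fold lower number from compound 1 to compound 2 (0.04 log units; within the scatter), a 1.4-fold higher number from compound 1 to compound 3 (0.15 log units; within the scatter) and a 1.6-fold higher number from compound 2 to compound 3 (0.19 log units; within the scatter). Compound 3 thus carries the highest of the three numbers, but its distance to compound 1 and to compound 2 lies within the scatter, so the three compounds cannot be told apart on these data.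

Compound 4, `COc1ncc(C(F)(F)F)cc1CO[C@H]1[C@H](C(C)(C)C)[C@@H](C(=O)O)N(C(=O)[C@@H]2CCCCO2)[C@H]1c1ccccc1Cl`, keeps the oxan-2-yl carbonyl of compound 3 and alters the phenyl ring: chloro in place of hydrogen on an aromatic carbon. Among the measured compounds shown here, no measured step touches this ring; every step so far concerns the acyl group, so none of them bears on the change from compound 3 to compound 4. The expectation therefore rests on compound 3 alone, with a wide range. Compound 4 is expected to give a step of a 1.0-fold higher number from compound 3 to compound 4 (0.01 log units; within the scatter) in this assay, not beyond the scatter in either direction. The estimate for compound 4 is 220 nM, with a range from 90 nM to 550 nM.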

Compound 4, half-maximal effective concentration: 222 nM
Compound 4: middle estimate off by 1.0-fold (0.00 log units), on the low side; low and high end bracket the measured number.
By their numbers in this assay, from the lowest: compounds 2, 1, 3 and 4 (each within the scatter of the next).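

Among the compounds shown here, the phenyl ring had not been touched by any earlier step, and in this assay going from phenyl to 2-chlorophenyl gives a 1.0-fold higher number from compound 3 to compound 4 (0.02 log units; within the scatter) and so the first reading at this ring. With the oxan-2-yl carbonyl kept in place, a chlorine atom on this aromatic carbon, ortho to a large group, therefore leaves no change that can be told from the scatter of the read-out, just as the exchanges of the acyl group before it left none. No measured evidence bears on why this substitution is tolerated here.

Going by these compounds, compounds 1 and 2 keep the unsubstituted phenyl ring, so it remains open whether the same chloro would be tolerated alongside the cyclohexyl or isopropoxy carbonyl groups. A single chlorine atom also says little about how far this place on the ring tolerates change, and the result leaves open what a methoxy group, a nitrile, an amine or a carboxylic acid would do there.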